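A few compounds are considered here, and "the series" means these few. Any claim that something is new, unique, unknown or untested is made for them only; others in the source may bear on it.

Measured in a functional assay on the whole organism with Rattus norvegicus as the target, in the maximal electroshock model; on this read-out higher numbers stand for an effect only at larger amounts of compound and lower numbers for an effect already at smaller amounts:

compound 1, `CNc1ncnc2c1ncn2Cc1ccccc1Cl`: 6.2 mg/kg
compound 2, `CNc1ncnc2c1ncn2Cc1ccc(F)cc1F`: 20 mg/kg
compound 3, `CCCNc1ncnc2c1ncn2Cc1ccccc1F`: 5.1 mg/kg

Compound 3 shows the lowest number of the three. Its value sits within the scatter of compound 1, while compound 2 stands beyond the scatter with a larger number. Compound 4, `CCN(C)c1ncnc2c1ncn2Cc1ccccc1F`, differs from compound 3 in one place: ethyl(methyl)amino in place of propylamino on an aromatic carbon. The two hold the same atoms, joined differently, and the single hydrogen-bond donor counted for propylamino is absent from ethyl(methyl)amino. Among the measured compounds shown here, no measured pair shows a change of this kind, so there is no direct comparison to lean on. A small step toward a larger number is expected, not far beyond the scatter: a 1.8-fold higher number from compound 3 to compound 4 (0.25 log units; within the scatter). In this assay compound 4 is estimated at 9 mg/kg, within a range from 3.5 mg/kg to 25 mg/kg.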

Compound 4, dose for half-maximal effect: 2.9 mg/kg
The estimate for compound 4 lay 3.1-fold (0.49 log units) above the measured number, and the stated range ends above it.
By their numbers in this assay, from the lowest: compounds 4, 3 and 1 (each within the scatter of the next, the first and the last beyond it); then compound 2.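

Moving from propylamino to ethyl(methyl)amino on this aromatic carbon keeps the same atoms but removes the hydrogen-bond donor, and in this assay the step reads a 1.8-fold lower number from compound 3 to compound 4 (0.25 log units; within the scatter) and so cannot be told from repeat-measurement noise. At this position, then, the effect in the rat model does not depend on keeping that donor, at least in this pair. Nothing available explains why the two compounds read alike.

Still open, on these data alone, is how a ring amine such as pyrrolidine or a longer chain such as butylamino would read at this position. Also open, as far as these compounds go, is whether the same swap would read alike with a different halogen pattern on the other ring.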